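Swapping One Dimethoxyphenyl Group for Another

The source may hold more compounds than are shown below. What is called first, only, known or untested is meant among the compounds shown, and "the series" means these compounds.

In a functional assay on AGS cells (Homo sapiens) for antiproliferative activity, read by MTT assay, with a stated time of 48 h (a lower number here means a stronger inhibitor of growth, a higher number a weaker inhibitor of growth), compound 1 `COc1ccc(N(C)c2nc(Cl)nc3c2ncn3C)cc1` gives 260 nM. Compound 3 `COc1ccc(N(C)c2nc(Cl)nc3c2ncn3Cc2ccc(OC)c(OC)c2)cc1` gives 56000 nM, the higher of the two actual numbers in the set. Compound 2 `COc1ccc(Cn2cnc3c(N(C)c4ccc(OC)cc4)nc(Cl)nc32)cc1` reaches only a limit, > 100000 nM.

Placing a 4-methoxyphenyl on the saturated chain carbon bound to an aromatic nitrogen gave an at least 380-fold higher number from compound 1 to compound 2 (2.58 log units; beyond the scatter). A 3,4-dimethoxyphenyl at that place gave a 220-fold higher number from compound 1 to compound 3 (2.33 log units; beyond the scatter). Adding one methoxy on an aromatic carbon gave only an at least 1.7-fold lower number from compound 2 to compound 3 (0.25 log units; that floor lies within the scatter).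

Compound 4 `COc1ccc(N(C)c2nc(Cl)nc3c2ncn3Cc2cc(OC)cc(OC)c2)cc1` carries 3,5-dimethoxyphenyl in place of 3,4-dimethoxyphenyl at the same place: 3,5-dimethoxyphenyl in place of 3,4-dimethoxyphenyl on a saturated chain carbon bound to an aromatic nitrogen. The large steps concern the arrival of the methoxy-bearing phenyl group, which compound 4 retains. Within the data shown here, with compound 3 at 56000 nM and an at least 1.7-fold lower number from compound 2 to compound 3 (0.25 log units; that floor lies within the scatter) as the only step between compounds bearing such a group, no change beyond the scatter is expected in this assay. The expected outcome is a 1.0-fold lower number from compound 3 to compound 4 (0.01 log units; within the scatter). Compound 4 is estimated at 55000 nM, within an expected range of 20000 nM to 100000 nM.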

Compound 4, concentration for 50% growth inhibition: 69000 nM
The estimate for compound 4 lay 1.3-fold (0.10 log units) below the measured number; the measured number falls inside the stated range.
By their numbers in this assay, from the lowest: compound 1; then compounds 3 and 4 (each within the scatter of the next). At a limit, above all of these: compound 2.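

In this assay the 3,5-dimethoxyphenyl and 3,4-dimethoxyphenyl groups on a saturated chain carbon bound to an aromatic nitrogen cannot be told apart (a 1.2-fold higher number from compound 3 to compound 4 (0.09 log units; within the scatter)), so this change in where the two methoxy groups stand has no readable effect here. The large loss relative to compound 1 persists with the new arrangement (a 270-fold higher number from compound 1 to compound 4 (2.42 log units; beyond the scatter)), and it is similar in scale to the one seen with the 3,4-dimethoxyphenyl group (a 220-fold higher number from compound 1 to compound 3 (2.33 log units; beyond the scatter)). The remaining step can be read only as a floor (an at least 1.4-fold lower number from compound 2 to compound 4 (0.16 log units; that floor lies within the scatter)), because one of its two values is a limit: the limit of > 100000 nM in this assay, at which 1 of the 4 values shown sits.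

The compounds shown do not say why a methoxy-bearing phenyl group at this place costs so much. They also leave open whether an ethyl chain there, or an amine on the phenyl ring, would keep the number nearer that of compound 1.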